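From Ethoxy to Chloro: Expecting Little Change

The compounds below may be only part of what the source reports. "The series", "measured", "known", "first", "only" and "open" are said of these compounds alone.

Three measured compounds share one core and differ only in the ring attached to the carbonyl. Compound 1 `CCOc1ccc(C(=O)/C=C/c2c(/C=C/c3ccc(OC)cc3)cc(OC)cc2OC)cc1` gives 6.4 ug/mL in a functional assay on B16-F10 cells (Mus musculus) for antiproliferative activity, read by MTT assay, with a stated time of 48 h (on this read-out higher numbers stand for weaker inhibition and lower numbers for stronger inhibition), the highest of the three numbers, though all three lie within the scatter of one another. Compound 2 `COc1ccc(/C=C/c2cc(OC)cc(OC)c2/C=C/C(=O)c2ccccc2C)cc1` gives 6.1 ug/mL and compound 3 `COc1ccc(/C=C/c2cc(OC)cc(OC)c2/C=C/C(=O)c2ccc(OC)cc2)cc1` gives 5.8 ug/mL. The step of a 1.0-fold lower number from compound 1 to compound 2 (0.02 log units; within the scatter) and the step of a 1.1-fold lower number from compound 1 to compound 3 (0.04 log units; within the scatter) both stay within the scatter. Compound 4 `COc1ccc(/C=C/c2cc(OC)cc(OC)c2/C=C/C(=O)c2ccc(Cl)cc2)cc1` differs from compound 1 by chloro in place of ethoxy on an aromatic carbon. The two measured changes at this same ring produced nothing beyond the scatter, so none is expected here either. The expected step is a 1.1-fold lower number from compound 1 to compound 4 (0.03 log units; within the scatter). Compound 4 is therefore estimated at 6 ug/mL, with a range from 3 ug/mL to 12 ug/mL.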

Compound 4, half-maximal inhibitory concentration: 4.9 ug/mL
Beside the measured number, compound 4's estimate is 1.2-fold (0.09 log units) above it; measured number inside the range.
By their numbers in this assay, from the lowest: compounds 4, 3, 2 and 1 (each within the scatter of the next).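

In this assay, chloro at this place, para to a large group, joins ethoxy, methoxy and the 2-methylphenyl ring without leaving the scatter: the steps read a 1.3-fold lower number from compound 1 to compound 4 (0.12 log units; within the scatter), a 1.2-fold lower number from compound 3 to compound 4 (0.07 log units; within the scatter) and a 1.2-fold lower number from compound 2 to compound 4 (0.10 log units; within the scatter). This ring position therefore accepts a chlorine atom as well as the carbon and oxygen groups seen earlier, with no measurable difference. No data here explain why these numbers stay so close. On these data alone, whether an amine or a carboxylic acid at this place would step beyond the scatter remains open.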